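Cutting the 3-methoxypropyl Chain Down to Methyl

The source may report more compounds than this note shows. Statements on the series, on what has been measured and on what is new or still open speak of the compounds shown alone.

Among the compounds with values here, compound 2 `CCCn1c(=O)n(CCCOC)c(=O)c2[nH]cnc21` has the lowest of the two numbers so far in a functional assay on the whole organism for inhibition, with Cavia porcellus as the target (a higher number here means that more compound is needed for the effect, a lower number that less compound is needed), at 0.72 mg/kg, while compound 1 `C=CCCn1c(=O)c2[nH]cnc2n(CCC)c1=O` gives 1.84 mg/kg. Compound 3 `CCCn1c(=O)n(C)c(=O)c2[nH]cnc21` carries hydrogen in place of 2-methoxyethyl on a saturated chain carbon bound to an aromatic nitrogen, so 3-methoxypropyl becomes methyl. Going by a 2.6-fold lower number from compound 1 to compound 2 (0.41 log units; beyond the scatter), the only measured step and a modest one on this chain, a step of similar size is expected, towards a higher number. The expected change is a 2.5-fold higher number from compound 2 to compound 3 (0.40 log units; beyond the scatter). For compound 3 the estimated value is 1.8 mg/kg, expected to fall between 0.6 mg/kg and 5.5 mg/kg.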

Compound 3, dose for half-maximal effect: 4.44 mg/kg
Compound 3: middle estimate off by 2.5-fold (0.39 log units), on the low side, within the range that was stated.
By their numbers in this assay, from the lowest: compound 2; then compound 1; then compound 3.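

Cutting the chain down to methyl gives the highest number of the three in this assay, with (a 6.2-fold higher number from compound 2 to compound 3 (0.79 log units; beyond the scatter)) and (a 2.4-fold higher number from compound 1 to compound 3 (0.38 log units; beyond the scatter)). At this position, then, both longer chains need less compound than methyl, whether the chain is 3-methoxypropyl or the unsaturated chain of compound 1. Nothing measured here explains this difference.

From the compounds shown here alone, whether chain length or the ether oxygen matters more remains open. A plain butyl chain, or a chain ending in an amine or a carboxylic acid, would help separate the two.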